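The source may report more compounds than this note shows. Statements on the series, on what has been measured and on what is new or still open speak of the compounds shown alone.

Compound 1 `O=S(=O)(NCCCNCc1ccccc1Cl)c1cc(C(F)(F)F)cc(C(F)(F)F)c1` gives 20000 nM in a functional assay on HT-29 cells (Homo sapiens) for inhibition, read by MTT assay, with a stated time of 72 h; on this read-out lower numbers stand for stronger inhibition of growth and higher numbers for weaker inhibition of growth. Compound 2 `CC(C)(C)c1ccc(CNCCCNS(=O)(=O)c2cc(C(F)(F)F)cc(C(F)(F)F)c2)cc1` gives 2000 nM and compound 3 `O=S(=O)(NCCCNCc1cccc2ccccc12)c1cc(C(F)(F)F)cc(C(F)(F)F)c1` gives 2600 nM. Compound 2 carries the lowest of the three numbers, but its gap to compound 3 lies within the scatter, so the two cannot be ordered; only its gap to compound 1 is beyond it. Compound 4 `O=S(=O)(NCCCNCc1ccc(-c2ccccc2)cc1)c1cc(C(F)(F)F)cc(C(F)(F)F)c1` is not yet measured and differs from compound 2 by phenyl in place of tert-butyl on an aromatic carbon. The steps of a 10-fold lower number from compound 1 to compound 2 (1.00 log units; beyond the scatter) and a 7.7-fold lower number from compound 1 to compound 3 (0.89 log units; beyond the scatter) show that exchanging the group on this chain carbon can shift the number markedly, whereas a 1.3-fold higher number from compound 2 to compound 3 (0.11 log units; within the scatter) shows two such exchanges giving near-identical numbers. For compound 4 a step within the scatter is expected, a 1.1-fold higher number from compound 2 to compound 4 (0.04 log units; within the scatter). Compound 4 is therefore estimated at 2200 nM, with a range of 900 nM to 5500 nM.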

Compound 4, concentration for 50% growth inhibition: 2300 nM
Estimate against measurement, compound 4: 1.0-fold (0.02 log units) below; low and high end bracket the measured number.
By their numbers in this assay, from the lowest: compounds 2, 4 and 3 (each within the scatter of the next); then compound 1.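

On this aromatic carbon, phenyl in place of tert-butyl gives a 1.2-fold higher number from compound 2 to compound 4 (0.06 log units; within the scatter) in this assay, so the two groups are not told apart here, although they differ in ring content and heavy-atom count. The earlier steps shown here exchanged the whole group on the chain carbon, whereas this one alters only the group on the aromatic ring. No measurement at hand bears on this result. Still open, from the compounds shown here alone, is whether a carboxylic acid or an amine in place of tert-butyl on this aromatic carbon would remain within the scatter of compound 2.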